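Removal of the furan methyl from compound 2

The source may report more compounds than this note shows. Statements on the series, on what has been measured and on what is new or still open speak of the compounds shown alone.

Compound 1 `Cc1ccc(-c2nc(N)c3nn(-c4ccccc4O)cc3n2)o1` gives 1% in an assay on CHO cells for displacement of a labelled ligand from adenosine receptor A1 (Homo sapiens), read by scintillation counting, with a stated time of 120 min, tested at 1 uM; on this read-out lower numbers stand for less inhibition and higher numbers for more inhibition at the one concentration tested (going by the name of the read-out).
Compound 2 `COc1ccccc1-n1cc2nc(-c3ccc(C)o3)nc(N)c2n1` gives 1% in this assay.

Among the measured compounds shown here, compound 2 stands level with compound 1; the only measured step, no change at the digits printed from compound 1 to compound 2 (within the scatter), lies within the scatter. Compound 3 `COc1ccccc1-n1cc2nc(-c3ccco3)nc(N)c2n1` differs from compound 2 by hydrogen in place of methyl on an aromatic carbon. For the measured compounds named here, no measured step touches this place, so the expectation rests on the flat behaviour of the pair so far. The step of a number 2 percentage points higher from compound 2 to compound 3 (within the scatter) is expected to stay within the scatter. Compound 3 is therefore estimated at 3%, in the range -8% to 15%.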

Compound 3, a percentage reported as inhibition, at one concentration (the size of the read-out at that concentration, not a potency): 31%
Estimate against measurement, compound 3: 28 percentage points below; measured number above the stated range.
By their numbers in this assay, from the lowest: compounds 1 and 2 (each within the scatter of the next); then compound 3.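

Hydrogen in place of methyl on the carbon next to the ring oxygen gives a number 30 percentage points higher from compound 2 to compound 3 (beyond the scatter) in this assay, so the 5-methylfuran-2-yl to furan-2-yl change is the first step in the series to exceed the scatter. This place on the furan therefore responds to substitution, whereas the change on the aromatic oxygen gave no change at the digits printed from compound 1 to compound 2 (within the scatter). No available data bear on the reason for this step. Still open, as far as these compounds go, is how an ethyl group, a chlorine or an amine at this place would compare with hydrogen and methyl. Also open, from the compounds shown here alone, is whether removing the methyl gives a similar step with the hydroxyl of compound 1 in place of the methoxy.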